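Hydroxamic acid series: removing the para chlorine of compound 3

This account rests on a few compounds, and the source may have more. Where it says the series, first, only, none or still open, it means among the compounds named here.

Working notes on cytotoxicity in a functional assay on cells (Cell line, Homo sapiens) for cytotoxicity, read by microscopy (a lower number here means that less compound is tolerated, a higher number that more compound is tolerated), for a small set sharing one core. Compound 1 `O=C(CCC1CCCC1)N(O)c1ccc(Cl)cc1` gives 100 ug/mL, compound 3 `O=C(CC1CCCCC1)N(O)c1ccc(Cl)cc1` gives 50 ug/mL, and compound 4 `O=C(CC1CCCCC1)N(O)c1ccccc1` has not yet been measured. Among the measured compounds shown here, compound 2 `O=C(C1CCCCC1)N(O)c1ccc(Cl)cc1` gives >= 20 ug/mL, which is a limit of this assay rather than a number, so only two numbers exist for comparison. Among those, compound 3 holds the lower one, but the step of a 2.0-fold lower number from compound 1 to compound 3 (0.30 log units; within the scatter) sits within the scatter, so compounds 1 and 3 cannot be ordered on it.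

The move from compound 3 to compound 4 is hydrogen in place of chloro on an aromatic carbon. For the measured compounds named here, no measured step in this set touches that aromatic position, so there is no direct guide, and the one step available, a 2.0-fold lower number from compound 1 to compound 3 (0.30 log units; within the scatter), was itself within the scatter. On that basis no step beyond the scatter is expected in this assay in either direction: the expected step of no change at the digits printed from compound 3 to compound 4 (within the scatter) is essentially flat. Compound 4 is therefore estimated at 50 ug/mL, with a range of 25 ug/mL to 100 ug/mL.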

Compound 4, minimum cytotoxic concentration: 100 ug/mL
Compound 4: middle estimate off by 2.0-fold (0.30 log units), on the low side, and the stated range covers the measured number.
By their numbers in this assay, from the lowest: compounds 3, 1 and 4 (each within the scatter of the next).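

Among the compounds shown here, for the first time the aromatic position, para to a large group, is changed, and in this assay hydrogen in place of chloro gives a 2.0-fold higher number from compound 3 to compound 4 (0.30 log units; within the scatter) on the shared core. This pair therefore shows no dependence of the read-out on the chlorine that can be told apart from repeat scatter, at least with the side chain of compound 3 in place. No available measurement bears on this step, and no cause can be assigned to it.

From the compounds shown here alone, whether a different group at this position, such as an amine or a carboxylic acid, would give a step beyond the scatter remains open, as does the effect of removing the chlorine with another side chain in place. Compound 2 gives >= 20 ug/mL in this assay, which is a limit and not a number.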